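From Methoxy to Dimethylamino: Expecting Little Change

The source may hold more compounds than are shown below. What is called first, only, known or untested is meant among the compounds shown, and "the series" means these compounds.

Three compounds share one core and differ in a single group on an outer aromatic ring: compound 1 (`CN(Cc1ccc(Cl)cc1)Cc1ccc(CNc2ccnc3cc(Cl)ccc23)cc1`) carries chloro, compound 2 (`CN(Cc1ccccc1)Cc1ccc(CNc2ccnc3cc(Cl)ccc23)cc1`) carries hydrogen, and compound 3 (`COc1ccc(CN(C)Cc2ccc(CNc3ccnc4cc(Cl)ccc34)cc2)cc1`) carries methoxy. In a physicochemical assay for acid dissociation, compound 1 gives 7.44 and compound 2 gives 7.56 while compound 3 gives 7.44 as its number, the same figure as compound 1. All three sit within the usual scatter of one another.

The next compound, compound 4 (`CN(Cc1ccc(CNc2ccnc3cc(Cl)ccc23)cc1)Cc1ccc(N(C)C)cc1`), keeps everything else but has dimethylamino in place of methoxy on an aromatic carbon, para to a large group (dimethylamino in place of methoxy on an aromatic carbon). The best guide is what exchanges at that same place have done so far: hydrogen for chloro (a number 0.12 log units higher from compound 1 to compound 2 (within the scatter)), methoxy for chloro (no change at the digits printed from compound 1 to compound 3 (within the scatter)) and methoxy for hydrogen (a number 0.12 log units lower from compound 2 to compound 3 (within the scatter)). None of these steps leaves the scatter. Among the compounds with values here, no measured compound carries dimethylamino there, so the range is kept wider than those steps alone would suggest. The step of a number 0.06 log units higher from compound 3 to compound 4 (within the scatter) is therefore expected to stay within the scatter, with no firm direction. Compound 4 is estimated at 7.5 with a likely range of 7.2 to 7.85 in the same measurement.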

Compound 4, acid dissociation constant: 7.33
Compound 4: the middle estimate sits 0.17 log units above what was measured; the measured number falls inside the stated range.
By their numbers in this assay, from the lowest: compounds 4, 1, 3 and 2 (each within the scatter of the next).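

In this assay, dimethylamino is the only group shown at this place that brings in a nitrogen atom, and it has one more heavy atom than methoxy, yet the steps read a number 0.11 log units lower from compound 3 to compound 4 (within the scatter), a number 0.11 log units lower from compound 1 to compound 4 (within the scatter) and a number 0.23 log units lower from compound 2 to compound 4 (within the scatter). Even the largest of these three steps stays within the scatter, so hydrogen, chloro, methoxy and dimethylamino, on an aromatic carbon para to a large group, cannot be told apart by this number, and no compound shown goes against that reading. Nothing further is available to explain why these four compounds cannot be separated.

The compounds shown leave open whether a carboxylic acid or a longer chain ending in an amine at this same place would carry the number in this assay beyond the scatter. They also vary only this one place, so what the exchange of methoxy for dimethylamino would do elsewhere on the molecule remains an open question.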